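Working notes: 2-methoxyphenyl to 4-methoxyphenyl

This account rests on a few compounds, and the source may have more. Where it says the series, first, only, none or still open, it means among the compounds named here.

Measured so far in a functional assay on NCI-H460 cells (Homo sapiens) for antiproliferative activity; a lower number here means a stronger inhibitor, a higher number a weaker inhibitor
- compound 1 (`N#CN/C(=N\CCCCCCCOc1ccccc1)Nc1cccnc1`): 360 nM
- compound 2 (`COc1ccccc1OCCCCCC/N=C(\NC#N)Nc1ccncc1`): 21 nM

Compound 2 holds the lower of the two numbers, and the gap to compound 1 lies beyond the scatter. Compound 3 (`COc1ccc(OCCCCCC/N=C(\NC#N)Nc2ccncc2)cc1`) carries 4-methoxyphenyl in place of 2-methoxyphenyl on an oxygen on a saturated carbon. Going by the values given here, no measured pair shows this change, so the expectation is loose: no shift beyond the scatter in this assay, with only a slight lean towards a higher number. The estimated step (a 1.2-fold higher number from compound 2 to compound 3 (0.08 log units; within the scatter)) is therefore small. Compound 3 is expected at 25 nM (estimated range 6 nM to 100 nM).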

Compound 3, half-maximal inhibitory concentration: 37 nM
Compound 3: the middle estimate sits 1.5-fold (0.17 log units) below what was measured; low and high end bracket the measured number.
By their numbers in this assay, from the lowest: compounds 2 and 3 (each within the scatter of the next); then compound 1.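

In this assay, going by these compounds alone, the exchange of 2-methoxyphenyl for 4-methoxyphenyl on this oxygen gives a 1.8-fold higher number from compound 2 to compound 3 (0.25 log units; within the scatter) and is the first single-place change readable. The two methoxyphenyl groups therefore cannot be told apart in this assay, so this position accepts either one without a shift beyond the scatter. No available evidence bears on this result.

Still open, going by these compounds, is how a hydroxyl or an ethoxy group would read in place of methoxy on this ring. Also open, on these data alone, is whether the same exchange stays within the scatter with a longer chain.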